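This account rests on a few compounds, and the source may have more. Where it says the series, first, only, none or still open, it means among the compounds named here.

In an assay on HEK293 cells for inhibition of N-acylethanolamine-hydrolyzing acid amidase (Rattus norvegicus), read by LC-MS, with a stated time of 30 min (a lower number here means a stronger inhibitor, a higher number a weaker inhibitor), compound 1 `O=C(CCCCCCc1ccccc1)N1CCCC1` gives 12900 nM and compound 2 `Cc1cccc(-c2ccc(CCC(=O)N3CCCC3)cc2)c1` gives 16500 nM. Compound 2 has the highest of the two numbers, with compound 1 nearest and within the scatter, so no order between the two is claimed. Compound 3 `O=C(CCc1ccc(-c2cccnc2)cc1)N1CCCC1` carries pyridin-3-yl in place of 3-methylphenyl on an aromatic carbon. Among the compounds with values here, no measured pair shows this change, so for compound 3 in this assay the expected step is put at none beyond the scatter, a 1.1-fold lower number from compound 2 to compound 3 (0.04 log units; within the scatter). Compound 3 is therefore expected near 15000 nM, with a range from 5000 nM to 50000 nM.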

Compound 3, half-maximal inhibitory concentration: > 100000 nM
Compound 3: only a limit was reported; the forecaster's own chance of this, stated with the estimate: 15%; middle value at least 6.6-fold (0.82 log units) away from the limit.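

On this aromatic carbon, pyridin-3-yl in place of 3-methylphenyl gives, in this assay, an at least 6.0-fold higher number from compound 2 to compound 3 (0.78 log units; beyond the scatter). Within the data shown here, this is the only step so far, and it shows that the group at this position can move the number beyond the scatter, which compounds 1 and 2 could not show. Compound 3 has a limit, not a number: the limit of > 100000 nM in this assay, at which 1 of the 3 values shown sits.

The change swaps the ring carbon for nitrogen and removes the methyl together, and the compounds shown do not separate the two. A plain phenyl or a 5-methylpyridin-3-yl on this carbon would tell them apart.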